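Amide variation on the shared core: compound 2 to compound 3

A few compounds are considered here, and "the series" means these few. Any claim that something is new, unique, unknown or untested is made for them only; others in the source may bear on it.

Going by the values given here, compound 2 `O=C1Nc2ccc(C(=O)NCc3ccccc3)cc2/C1=C/c1cc(Cl)c(O)c(Cl)c1` stands lowest of the two numbers so far: in an assay on HeLa cells for inhibition of Kinesin-like protein KIF15 (Homo sapiens), read by microscopy, with stated times of 2 s and 20 s, tested at 750 nM (a higher number here means more inhibition at the concentration tested (going by the name of the read-out), a lower number less inhibition), compound 2 gives -24%. Among the compounds with values here, the nearest number is that of compound 1 `O=C1Nc2ccc(C(=O)c3ccco3)cc2/C1=C/c1cc(Br)c(O)c(Br)c1`, which in this assay gives 65%, a gap beyond the scatter; no single-change step links the two. Compound 3 `O=C1Nc2ccc(C(=O)N3CCCC3)cc2/C1=C/c1cc(Cl)c(O)c(Cl)c1` differs from compound 2 by pyrrolidin-1-yl in place of benzylamino on a carbonyl carbon. Within the data shown here, no measured step of this kind exists, so the step in this assay cannot be read from the data; nothing beyond the scatter is expected, at most a small rise. Compound 3 is expected to give -5%, between -40% and 35%, the estimated step being a number 19 percentage points higher from compound 2 to compound 3 (beyond the scatter).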

Compound 3, a percentage reported as inhibition, at one concentration (the size of the read-out at that concentration, not a potency): -10%
The estimate for compound 3 lay 5 percentage points above the measured number; measured number inside the range.
By their numbers in this assay, from the lowest: compound 2; then compound 3; then compound 1.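

In this assay, pyrrolidin-1-yl in place of benzylamino on a carbonyl carbon gives a number 14 percentage points higher from compound 2 to compound 3 (beyond the scatter), the only single-change step shown, so this position responds to the amide group. The response remains modest: compound 2 gives -24%, and compound 3 still gives -10%, with neither amide showing positive inhibition. No evidence available here bears on the origin of this step.

Open, going by these compounds, is how a morpholine amide or a carboxylic acid at this carbonyl carbon would read. Also open, on these data alone, is whether the step holds with bromine in place of chlorine on the shared core.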